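Stereocentre inversion at the ring alcohol of compound 3

The compounds below may be only part of what the source reports. "The series", "measured", "known", "first", "only" and "open" are said of these compounds alone.

Of the compounds shown here, three have been measured in a functional assay on HCT-116 cells (Homo sapiens) for cytotoxicity, read by sulforhodamine B assay, with a stated time of 2 days; on this read-out higher numbers stand for weaker inhibition and lower numbers for stronger inhibition. Compound 1 `OC1CCCc2nc(-c3ccc(N4CCCC4)cc3)sc21` gives > 100000 nM in this assay, which is a limit of the assay and not a number. Among the compounds with values here, compound 2 `OC1CNCc2nc(-c3ccc(N4CCCC4)cc3)sc21` gives 25000 nM in this assay, the only numerical value so far. Compound 3 `Cc1cc(N(C)C)ccc1-c1nc2c(s1)[C@H](O)CCC2` gives > 100000 nM in this assay; this is again a limit and not a number. Compound 3 thus stands at the weak end of what is shown, described by the limit of > 100000 nM in this assay, at which 2 of the 3 values shown sit. Within the data shown here, no pair of measured compounds differs in a single place, so no measured step size is available to guide the next change.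

Compound 4 `Cc1cc(N(C)C)ccc1-c1nc2c(s1)[C@@H](O)CCC2` is the unmeasured counterpart of compound 3: the two compounds have the same atoms and bonds and differ only in configuration as drawn: 1 of 1 stereo elements differ; a stereocentre at a saturated ring carbon is drawn R in compound 3 and S in compound 4. Since compound 3 sits at the limit, the inversion is expected to produce no step beyond the scatter, and the most likely outcome for compound 4 is a further limit. The expected move is a number no higher from compound 3 to compound 4 (the limit leaves the size open). Compound 4 is estimated at 100000 nM in this assay, within 25000 nM to 300000 nM.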

Compound 4, half-maximal inhibitory concentration: 127000 nM
For compound 4 the middle estimate is 1.3-fold (0.10 log units) below the measured one, within the range that was stated.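

In this assay, within the data shown here, compound 3 gives > 100000 nM, a limit and not a number, so no step to compound 4 can be read. The compounds shown leave open whether inverting the stereocentre at the ring alcohol changes cytotoxicity at all.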